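Methoxy in place of methylsulfanyl on compound 1

The source may report more compounds than this note shows. Statements on the series, on what has been measured and on what is new or still open speak of the compounds shown alone.

Measured compounds:
- compound 1 `CSc1ccc(CNc2nc(SC)nc3ncccc23)cc1`: 7030 nM
- compound 2 `C[Se]c1nc([Se]C)c2cccnc2n1`: "not determined" (no result reported)
- compound 3 `CSc1ccc(CNc2nc([SeH])nc3ccccc23)cc1`: > 100000 nM

In a functional assay on HT-29 cells (Homo sapiens) for cytotoxicity, read by MTT assay, with a stated time of 72 h (on this read-out lower numbers stand for stronger inhibition of growth and higher numbers for weaker inhibition of growth), compound 1 gives 7030 nM. For compound 2 the outcome in this assay is "not determined" (no result reported). Compound 3 gives only > 100000 nM, which is a limit of this assay and not a number. Compound 1 therefore holds the only single number shown; one further value is a limit and one entry carries no number at all. For the measured compounds named here, no two measured compounds differ in just one place, so no measured step is available.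

The unmeasured compound 4 `COc1ccc(CNc2nc(SC)nc3ncccc23)cc1` differs from compound 1 in one place: methoxy in place of methylsulfanyl on an aromatic carbon. Going by the values given here, with no measured pair showing this change, the expected step from compound 1 to compound 4 is a 1.1-fold higher number from compound 1 to compound 4 (0.03 log units; within the scatter), that is, no shift beyond the usual scatter in either direction. Compound 4 is accordingly estimated at 7500 nM, with a range from 2500 nM to 25000 nM.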

Compound 4, concentration for total growth inhibition: > 100000 nM
Compound 4: a limit, no number; the forecaster's own chance of this, stated with the estimate: 10%; at least 13-fold (1.12 log units) between middle value and limit.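

In this assay the change from methylsulfanyl to methoxy on an aromatic carbon, para to a large group, gives an at least 14-fold higher number from compound 1 to compound 4 (1.15 log units; beyond the scatter) even though the two groups match in heavy-atom and hydrogen-bond acceptor counts. For compound 4 the entry > 100000 nM is a limit of the assay and not a number. On these data alone, the step therefore gives only a lower bound, so the full effect of this swap of sulfur for oxygen stays unknown, because compound 4 sits at a limit: the limit of > 100000 nM in this assay, at which 2 of the 4 values shown sit.

The compounds shown leave open whether this position needs sulfur specifically or whether a chlorine atom, an ethylsulfanyl group or an amine could serve as well. They also leave open whether the same swap at the methylsulfanyl on the core would matter as much.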